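A naphthalen-1-yl in place of phenyl on a carbonyl carbon

A few compounds are considered here, and "the series" means these few. Any claim that something is new, unique, unknown or untested is made for them only; others in the source may bear on it.

In a functional assay on CCRF-CEM cells (Homo sapiens) for inhibition (a higher number here means a weaker inhibitor, a lower number a stronger inhibitor), compound 1 `Cn1cc(C#N)c2ccc(Nc3ncc(-c4ccccc4)o3)cc21` gives 8000 nM and compound 2 `Cn1cc(C#N)c2ccc(Nc3ncc(-c4cccc(CNC(=O)c5ccccc5)c4)o3)cc21` gives 5300 nM. For the measured compounds named here, the two numbers differ by a 1.5-fold lower number from compound 1 to compound 2 (0.18 log units; within the scatter), so compound 2 cannot be told apart from compound 1, the only other compound measured. That step put benzamidomethyl in place of hydrogen on an aromatic carbon.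

Compound 3 `Cn1cc(C#N)c2ccc(Nc3ncc(-c4cccc(CNC(=O)c5cccc6ccccc56)c4)o3)cc21` differs from compound 2 in one place: naphthalen-1-yl in place of phenyl on a carbonyl carbon. Going by the values given here, no measured step changes this group directly. The nearest evidence is the step that brought in the benzamidomethyl group, a 1.5-fold lower number from compound 1 to compound 2 (0.18 log units; within the scatter), and it stayed small. On that slender basis, no step beyond the scatter is expected in this assay, and no direction is firmly indicated. The estimated step is a 1.2-fold lower number from compound 2 to compound 3 (0.07 log units; within the scatter). The expected value for compound 3 is 4500 nM, with an estimated range of 1800 nM to 11000 nM.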

Compound 3, half-maximal inhibitory concentration: 2500 nM
Beside the measured number, compound 3's estimate is 1.8-fold (0.26 log units) above it, within the range that was stated.
By their numbers in this assay, from the lowest: compound 3; then compounds 2 and 1 (each within the scatter of the next).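

Going from phenyl to naphthalen-1-yl on the carbonyl carbon gives a 2.1-fold lower number from compound 2 to compound 3 (0.33 log units; beyond the scatter) in this assay and is the first step among these compounds to pass beyond the scatter. The step that brought in the benzamidomethyl group, a 1.5-fold lower number from compound 1 to compound 2 (0.18 log units; within the scatter), could not show that the number responds to this part of the molecule, whereas this change shows a modest response to the group on the carbonyl carbon. Nothing available bears on the reason for this step.

On these data alone, it remains open what a naphthalen-2-yl, a quinolinyl or a small methyl on the same carbonyl carbon would do to the number. As far as these compounds go, it also remains open whether the amide link itself matters, as a sulfonamide or a urea in its place would test.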